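The source may report more compounds than this note shows. Statements on the series, on what has been measured and on what is new or still open speak of the compounds shown alone.

Measured compounds:
compound 1, `O=C(/C=C/c1cn(-c2ccccc2)nc1-c1cccnc1)c1ccccn1`, with 6400 nM in a functional assay on Huh-7 cells (Homo sapiens) for inhibition, read by sulforhodamine B assay, with a stated time of 72 h; on this read-out higher numbers stand for weaker inhibition and lower numbers for stronger inhibition
compound 2, `O=C(/C=C/c1cn(-c2ccccc2)nc1-c1cccnc1)c1cc[nH]c1`, with 3300 nM in this assay

Within the data shown here, compound 2 gives the lower of the two numbers so far, but the step from compound 1 to compound 2, a 1.9-fold lower number from compound 1 to compound 2 (0.29 log units; within the scatter), lies within the scatter, so the two compounds are not separated by this measurement.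

Compound 3, `O=C(/C=C/c1cn(-c2ccccc2)nc1-c1cccnc1)c1c[nH]c2ccccc12`, is not yet measured. It differs from compound 2 in one place: 1H-indol-3-yl in place of 1H-pyrrol-3-yl on a carbonyl carbon.

Among the measured compounds shown here, only one measured step exists, and it concerns a different exchange on the same carbonyl carbon; it was a 1.9-fold lower number from compound 1 to compound 2 (0.29 log units; within the scatter), within the scatter. For the measured compounds named here, no measured pair shows what a pyrrole-to-indole exchange does here. A modest step in this assay, in either direction or none beyond the scatter, is therefore expected. Compound 3 is estimated at 2500 nM, in the range 800 nM to 8000 nM. This estimate implies a step of a 1.3-fold lower number from compound 2 to compound 3 (0.12 log units; within the scatter).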

Compound 3, half-maximal inhibitory concentration: 3200 nM
Compound 3: middle estimate off by 1.3-fold (0.11 log units), on the low side; the range from low to high includes it.
By their numbers in this assay, from the lowest: compounds 3, 2 and 1 (each within the scatter of the next).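

On the carbonyl carbon, 1H-indol-3-yl brings a six-membered aromatic ring of carbon only that 1H-pyrrol-3-yl lacks, yet this larger group gives a 1.0-fold lower number from compound 2 to compound 3 (0.01 log units; within the scatter) in this assay, so the extra ring does not separate the two compounds. Set against pyridin-2-yl, the same group gives a 2.0-fold lower number from compound 1 to compound 3 (0.30 log units; within the scatter), which leaves all three groups at this position unseparated by this measurement. No supporting data bear on why the extra ring leaves the number so little altered.

The compounds shown leave open whether any group at this position would move the number beyond the scatter, such as an open-chain amine or a carboxylic acid on the indole. They also leave open whether changes elsewhere on the shared core would do so.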